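Changing the Side Chain on a Shared Core

The source may hold more compounds than are shown below. What is called first, only, known or untested is meant among the compounds shown, and "the series" means these compounds.

Measured in a functional assay on MCF7 cells (Homo sapiens) for cytotoxicity, read by fluorescence, with a stated time of 72 h; a lower number here means a stronger inhibitor, a higher number a weaker inhibitor:
compound 1 `CC(C)c1n[nH]c2c(NCc3ccc(-c4ccccn4)cc3)nc(NCCO)nc12`: 51 nM
compound 2 `CC(C)c1n[nH]c2c(NCc3ccc(-c4ccccn4)cc3)nc(NCCN(C)C)nc12`: 225 nM

Of these two, compound 2 at 225 nM has the higher number, which makes it the weaker inhibitor. Compound 3 `CC(C)c1n[nH]c2c(NCc3ccc(-c4ccccn4)cc3)nc(NCc3ccc(-c4ccccn4)cc3)nc12` has not yet been measured. Its change from compound 2 is 4-(pyridin-2-yl)phenyl in place of (dimethylamino)methyl on a saturated chain carbon bound to a nitrogen on an aromatic ring. For the measured compounds named here, the only measured step, a 4.4-fold higher number from compound 1 to compound 2 (0.64 log units; beyond the scatter), altered the same chain and was modest. Going by the values given here, no measured step tests this swap directly, so the direction is uncertain, but a similarly modest rise seems the best guess. The expected step is a 2.2-fold higher number from compound 2 to compound 3 (0.35 log units; beyond the scatter). For compound 3 the estimated value is 500 nM, with an expected range of 100 nM to 2500 nM.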

Compound 3, half-maximal inhibitory concentration: 2390 nM
For compound 3 the middle estimate is 4.8-fold (0.68 log units) below the measured one, within the range that was stated.
By their numbers in this assay, from the lowest: compound 1; then compound 2; then compound 3.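

In this assay this place on the side chain tolerates the much larger 4-(pyridin-2-yl)phenyl poorly: the swap gives an 11-fold higher number from compound 2 to compound 3 (1.03 log units; beyond the scatter), a large step where the earlier change was modest. Measured against the hydroxymethyl group, the same group gives a 47-fold higher number from compound 1 to compound 3 (1.67 log units; beyond the scatter), so a second large aromatic unit is the least favourable of the three side chains shown. Nothing available explains this loss. The compounds shown leave open whether a single phenyl ring, or a longer chain ending in hydroxy, would behave more like compound 1 or like compound 3.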